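The source may hold more compounds than are shown below. What is called first, only, known or untested is meant among the compounds shown, and "the series" means these compounds.

Of the compounds shown here, three sharing one core have been tested in a functional assay on SK-BR-3 cells (Homo sapiens) for antiproliferative activity, read by MTT assay, with a stated time of 72 h; on this read-out higher numbers stand for weaker inhibition and lower numbers for stronger inhibition. Compound 1 `CCN(CC)CCNc1cc(C)c2cc(NC(=O)c3ccc(Cl)c(Cl)c3)ccc2n1` gives 3710 nM; compound 2 `CCN1CCN(c2cc(C)c3cc(NC(=O)c4ccc(OC)cc4)ccc3n2)CC1` gives 9000 nM; compound 3 `Cc1cc(N2CCCC2)nc2ccc(NC(=O)c3ccc(Cl)c(Cl)c3)cc12` gives 43400 nM. Among these three numbers, compound 2 stands second highest, with compound 1 below it and compound 3 above it, both gaps lying beyond the usual scatter.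

For the measured compounds named here, the only single change traced between two measured compounds is a 12-fold higher number from compound 1 to compound 3 (1.07 log units; beyond the scatter), and it concerns the pyrrolidin-1-yl and (2-(diethylamino)ethyl)amino groups, not the (4-methoxyphenyl)carbonyl part. Compound 4 `CCN1CCN(c2cc(C)c3cc(NC(=O)c4ccccc4)ccc3n2)CC1` differs from compound 2 in exactly that other part: hydrogen in place of methoxy on an aromatic carbon. Going by the values given here, no measured pair shows this change, so there is no direct guide to how the number will move.

With nothing comparable to lean on, the expectation is that the change leaves the number close to where compound 2 sits, and the step of no change at the digits printed from compound 2 to compound 4 (within the scatter) is expected to stay within the scatter of repeated measurements. Compound 4 is therefore estimated at 9000 nM in this assay, with a range from 4000 nM to 20000 nM.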

Compound 4, half-maximal inhibitory concentration: 18400 nM
Compound 4: middle estimate off by 2.0-fold (0.31 log units), on the low side; low and high end bracket the measured number.
By their numbers in this assay, from the lowest: compound 1; then compound 2; then compound 4; then compound 3.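

For the compounds shown here, measured in this assay, hydrogen in place of methoxy on an aromatic carbon para to a large group gives a 2.0-fold higher number from compound 2 to compound 4 (0.31 log units; beyond the scatter) and thus provides the first reading of a change at this end of the molecule. In this one pair, the compound that keeps the methoxy group is the stronger inhibitor, although the step is modest and much smaller than a 12-fold higher number from compound 1 to compound 3 (1.07 log units; beyond the scatter), a change made at a different place on the shared core. The measurements offer no explanation for the direction or size of the step from methoxy to hydrogen.

A single pair cannot show whether methoxy itself matters or whether another group at this place, such as fluorine, hydroxyl or dimethylamino, would give a similar or larger shift. As far as these compounds go, it also remains open whether the same change would have a comparable effect on a compound carrying the (2-(diethylamino)ethyl)amino group of compound 1, and compound 1 cannot settle this, as it differs from compound 2 and compound 4 in more than one place.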